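Sugar Replaces Protected Diol on a Shared Core

This account rests on a few compounds, and the source may have more. Where it says the series, first, only, none or still open, it means among the compounds named here.

Measured compounds:
compound 1 `CC1(C)OCC(Cn2cc(Cn3c4c(c5ccccc53)C(=O)c3c[n+]([O-])c5ccccc5c3C4=O)nn2)O1`: 330 nM
compound 2 `O=C1c2c[n+]([O-])c3ccccc3c2C(=O)c2c1c1ccccc1n2CCN1CCCC1`: 430 nM

Both compounds were tested in a functional assay on A-375 cells (Homo sapiens) for cytotoxicity, read by MTT assay, with a stated time of 72 h; a higher number here means a weaker inhibitor, a lower number a stronger inhibitor. In this assay compound 1 gives 330 nM, the lowest of the two numbers, while compound 2 gives 430 nM; the two values lie within the usual scatter of each other, so neither can be called stronger.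

Compound 3 `O=C1c2c[n+]([O-])c3ccccc3c2C(=O)c2c1c1ccccc1n2Cc1cn([C@@H]2O[C@H](CO)[C@@H](O)[C@H](O)[C@H]2O)nn1` has not yet been measured. It differs from compound 1 in one place:
3,4,5-trihydroxy-6-(hydroxymethyl)oxan-2-yl in place of (2,2-dimethyl-1,3-dioxolan-4-yl)methyl on an aromatic nitrogen

Going by the values given here, no measured pair shows a comparable change, so nothing here tells how large this step will be or in which direction. With only that to go on, a modest weakening is expected, and the estimated step of a 1.8-fold higher number from compound 1 to compound 3 (0.26 log units; within the scatter) is small but may exceed the scatter. Compound 3 is therefore expected to give about 600 nM in this assay, within a range from 200 nM to 2000 nM.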

Compound 3, half-maximal inhibitory concentration: 230 nM
Estimate against measurement, compound 3: 2.6-fold (0.42 log units) above; the measured number falls inside the stated range.
By their numbers in this assay, from the lowest: compounds 3, 1 and 2 (each within the scatter of the next).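

Placing 3,4,5-trihydroxy-6-(hydroxymethyl)oxan-2-yl in place of (2,2-dimethyl-1,3-dioxolan-4-yl)methyl on the aromatic nitrogen gives a 1.4-fold lower number from compound 1 to compound 3 (0.16 log units; within the scatter) in this assay, a step that stays within the usual scatter. At this place, then, a group with 4 hydrogen-bond donors and a group with 0 hydrogen-bond donors give numbers that cannot be told apart, even though the two groups differ in ring size and heavy-atom count. Nothing measured here offers an explanation for this result.

Going by these compounds, one sugar says little about sugars in general, so it remains open whether a different sugar would give a similar number. On these data alone, it is equally open whether a carboxylic acid or a simple amine on this same nitrogen would fit the same picture.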